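Adding an Amino Group to a Chloropurine Benzyl Series

The compounds below may be only part of what the source reports. "The series", "measured", "known", "first", "only" and "open" are said of these compounds alone.

Measured compounds:
- compound 1, `ClCc1ccc(Cn2cnc3c(Cl)ncnc32)cc1`: 4360 nM
- compound 2, `ClCc1cccc(Cn2cnc3c(Cl)nc(Cl)nc32)c1`: 3230 nM
- compound 3, `Nc1nc(Cl)c2ncn(Cc3ccccc3CCl)c2n1`: 26900 nM

Three compounds sharing a fused bicyclic core carrying a chloro group, each with a benzyl arm bearing a chloromethyl group, have been tested in a functional assay on MDA-MB-435 cells (Homo sapiens) for cytotoxicity, read by sulforhodamine B assay, with a stated time of 48 h; a higher number here means a weaker inhibitor of growth, a lower number a stronger inhibitor of growth. Compound 1 gives 4360 nM, and compound 2 gives 3230 nM; the gap between these two lies within the usual scatter, so nothing separates them. Compound 3, which carries an amino group on the core, gives 26900 nM, a number well above that of compound 1 and beyond the scatter. Compound 3 differs from compound 1 in more than one place, so its higher number cannot be pinned on the amino group alone.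

Compound 4, `Nc1nc(Cl)c2ncn(Cc3ccc(CCl)cc3)c2n1`, is the next compound to be examined. It differs from compound 1 by a single change: amino in place of hydrogen on an aromatic carbon. Within the data shown here, with no pair of measured compounds differing only in this way, the direction of the step in this assay must be judged from compound 3. Because compound 3 gives 26900 nM, the amino-bearing analogue compound 4 is expected to give a higher number than compound 1, by a step of a 2.5-fold higher number from compound 1 to compound 4 (0.40 log units; beyond the scatter). Compound 4 is therefore estimated at 11000 nM, in a range from 3500 nM to 35000 nM.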

Compound 4, concentration for total growth inhibition: 42700 nM
Compound 4: middle estimate off by 3.9-fold (0.59 log units), on the low side; the measured number lies above the stated range.
By their numbers in this assay, from the lowest: compounds 2 and 1 (each within the scatter of the next); then compounds 3 and 4 (each within the scatter of the next).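

In this assay, amino in place of hydrogen on the aromatic carbon between two ring nitrogen atoms gives a 9.8-fold higher number from compound 1 to compound 4 (0.99 log units; beyond the scatter), so this single change, with the rest of compound 1 left as it is, goes with weaker inhibition of growth. Compound 3 could not show this, since it differs from compound 1 in more than one place; the one-place pair now ties a step beyond the scatter to the amino group itself, and the numbers of compound 3 and compound 4 lie within the scatter of each other. Nothing measured here speaks to why amino at this carbon has this result.

From the compounds shown here alone, one pair gives one step on one core, so it remains open whether the step is particular to amino or would also appear with a small group such as methyl, hydroxyl or methoxy at the same carbon. Going by these compounds, it also remains open whether a larger amine, such as dimethylamino, would give a number nearer to that of compound 1 or further from it.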